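A further hydroxy on the core of compound 1

The compounds below may be only part of what the source reports. "The series", "measured", "known", "first", "only" and "open" are said of these compounds alone.

Measured compounds:
- compound 1 `O=c1oc2ccccc2cc1Oc1ccc(Cl)cc1O`: 108000 nM
- compound 2 `O=c1oc2ccc(O)cc2cc1Oc1ccc(Cl)cc1O`: 134000 nM

Both values come from an ADME assay on L6 cells (Rattus norvegicus) for inhibition, read by fluorescence, with a stated time of 72 h; a lower number here means a stronger inhibitor, a higher number a weaker inhibitor. Only these two compounds have been measured, and they lie within the scatter of each other, so neither can be ranked above the other. Compound 1 therefore has no clear place of its own on these numbers.

Compound 3 `O=c1oc2cc(O)ccc2cc1Oc1ccc(Cl)cc1O` has not been measured yet. It differs from compound 1 by one change: hydroxy in place of hydrogen on an aromatic carbon. Hydroxy stands in place of hydrogen on an aromatic carbon of a six-membered aromatic ring of carbon only, part of a fused or bridged system of two rings.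

Among the measured compounds shown here, the one measured step of the same kind, a 1.2-fold higher number from compound 1 to compound 2 (0.09 log units; within the scatter), places its hydroxy on a different carbon. It gives no reason to expect a change beyond the scatter in this assay, though a single step is thin evidence. The expected change is a 1.1-fold higher number from compound 1 to compound 3 (0.05 log units; within the scatter). For compound 3 the estimate is 120000 nM, with an expected range of 60000 nM to 240000 nM.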

Compound 3, half-maximal inhibitory concentration: 144000 nM
For compound 3 the middle estimate is 1.2-fold (0.08 log units) below the measured one; measured number inside the range.
By their numbers in this assay, from the lowest: compounds 1, 2 and 3 (each within the scatter of the next).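

In this assay, hydroxy in place of hydrogen at this carbon gives a step that lies within the scatter (a 1.3-fold higher number from compound 1 to compound 3 (0.12 log units; within the scatter)), as does the earlier step at a different carbon (a 1.2-fold higher number from compound 1 to compound 2 (0.09 log units; within the scatter)). Compound 2 alone could speak for only one carbon, whereas two carbons of the core of compound 1 have now taken a hydroxy without a change beyond the scatter. This holds for these two carbons and this one group only, and no measurement shown offers an explanation for it.

Still open, on these data alone, is whether another group at these carbons, such as an amine or a carboxylic acid, would give a step beyond the scatter. Also open, as far as these compounds go, is whether hydroxy on the remaining carbons of this ring would stay within the scatter too.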